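From thiophen-2-yl to phenyl at the assay limit

A few compounds are considered here, and "the series" means these few. Any claim that something is new, unique, unknown or untested is made for them only; others in the source may bear on it.

- Compound 1 (`COc1ncnc2c1c(-c1ccccc1)cn2[C@@H]1O[C@H](CO)[C@@H](O)[C@H]1O`): > 100000 nM
- Compound 2 (`CSc1ncnc2c1c(-c1cccs1)cn2[C@@H]1O[C@H](CO)[C@@H](O)[C@H]1O`): > 100000 nM

In an ADME assay on MRC5 cells (Homo sapiens), read by MTT assay, with a stated time of 72 h (on this read-out higher numbers stand for weaker inhibition and lower numbers for stronger inhibition), compound 2 gives > 100000 nM as a limit and not as a number. Going by the values given here, its standing is the limit of > 100000 nM in this assay, at which 2 of the 2 values shown sit, and no step between measured compounds can be read from that. Compound 3 (`CSc1ncnc2c1c(-c1ccccc1)cn2[C@@H]1O[C@H](CO)[C@@H](O)[C@H]1O`) has phenyl in place of thiophen-2-yl on an aromatic carbon. Compound 1 also carries phenyl and gives > 100000 nM as a limit too. No change beyond the scatter is expected in this assay from this exchange, and a further limit is the likeliest report. For compound 3 the estimated value is 100000 nM with an expected range from 40000 nM to 200000 nM on this reading.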

Compound 3, half-maximal inhibitory concentration: > 100000 nM
Compound 3 ended at the assay's limit; the forecaster's own chance of this, stated with the estimate: 80%; the middle value lies on the limit itself.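

Neither the step from compound 2 to compound 3 nor the step from compound 1 to compound 3 can be read, because all three compounds stand at one limit: the limit of > 100000 nM in this assay, at which 3 of the 3 values shown sit. The compounds shown leave open whether phenyl and thiophen-2-yl, or methoxy and methylsulfanyl, differ at all on this read-out.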